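The compounds below may be only part of what the source reports. "The series", "measured", "known", "first", "only" and "open" are said of these compounds alone.

Working notes on the series.

Compound 1 `CCCCCCCCCC(CCO)n1cnc2c(N)ncnc21` is the reference of the set. In a functional assay on SW480 cells (Homo sapiens) for antiproliferative activity, read by MTT assay, with a stated time of 48 h (a higher number here means a weaker inhibitor, a lower number a stronger inhibitor), compound 1 gives 6030 nM. For the measured compounds named here, compound 2 `CCCCCCCCCC(CCO)n1cnc2c(N)nc(Cl)nc21` differs from compound 1 only by chloro in place of hydrogen on an aromatic carbon; in this assay compound 2 gives 12200 nM, and the step of a 2.0-fold higher number from compound 1 to compound 2 (0.31 log units; beyond the scatter) is the one measured instance of this change so far. Compound 3 `CCCCCCCCCCCC(CCO)n1cnc2c(N)ncnc21` keeps the core of compound 1 and differs by ethyl in place of hydrogen on a saturated chain carbon, ten or more bonds along the chain from an aromatic nitrogen; in this assay compound 3 gives 11600 nM, and the step of a 1.9-fold higher number from compound 1 to compound 3 (0.28 log units; within the scatter) stays within the usual scatter, so the values of compound 1 and compound 3 are read as comparable. The values of compound 2 and compound 3 are likewise within the scatter of each other.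

Compound 4 `CCCCCCCCCCCC(CCO)n1cnc2c(N)nc(Cl)nc21` has not yet been measured. It differs from compound 3 by chloro in place of hydrogen on an aromatic carbon, which is the same change already made from compound 1 to compound 2, placed on the same aromatic carbon with the same surroundings. The two cores differ by ethyl in place of hydrogen on a saturated chain carbon, ten or more bonds along the chain from an aromatic nitrogen.

Going by the values given here, the expectation for compound 4 in this assay is a step of about a 1.9-fold higher number from compound 3 to compound 4 (0.28 log units; within the scatter), because a 2.0-fold higher number from compound 1 to compound 2 (0.31 log units; beyond the scatter) is the only measured instance of this change and nothing in the set points to a different behaviour on the longer chain. Compound 4 is therefore expected to give 22000 nM, with a likely range of 11000 nM to 45000 nM.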

Compound 4, half-maximal inhibitory concentration: 17800 nM
Compound 4: the middle estimate sits 1.2-fold (0.09 log units) above what was measured; low and high end bracket the measured number.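

In this assay, for the compounds shown here, chloro in place of hydrogen on the aromatic carbon gives a 1.5-fold higher number from compound 3 to compound 4 (0.19 log units; within the scatter), and this step agrees with the earlier one on the core of compound 1: the same change on two cores in this assay, a 2.0-fold higher number (0.31 log units; beyond the scatter) from compound 1 to compound 2 and a 1.5-fold higher number (0.19 log units; within the scatter) from compound 3 to compound 4, 1.3-fold (0.12 log units) apart, within the scatter of two such steps The ethyl extension of the saturated chain, read on the chloro-bearing core, gives a 1.5-fold higher number from compound 2 to compound 4 (0.16 log units; within the scatter), and it likewise agrees with its earlier counterpart: the same change on two cores in this assay, a 1.9-fold higher number (0.28 log units; within the scatter) from compound 1 to compound 3 and a 1.5-fold higher number (0.16 log units; within the scatter) from compound 2 to compound 4, 1.3-fold (0.12 log units) apart, within the scatter of two such steps The two changes therefore carry over from one core to the other within the scatter across these four compounds, but this rests on a single pair of cores, only one of the four steps lies beyond the scatter, and the data do not establish a reliable effect of chloro on the core of compound 3 or explain any of the steps.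

The compounds shown leave open whether the same transfer would hold for another group on that aromatic carbon, such as fluoro, bromo or an amine, and whether it would persist on a still longer chain or a much shorter one. They also leave open what happens when the terminal hydroxyl gives way to a carboxylic acid or an amine on either core.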